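The source may hold more compounds than are shown below. What is called first, only, known or untested is meant among the compounds shown, and "the series" means these compounds.

Working notes on a series of three measured compounds and one still to be measured. Compound 1 `FC(F)(F)c1ccc(/C=C\c2cc3ccccc3nc2Cl)cc1`, compound 2 `FC(F)(F)c1cccc(/C=C\c2cc3ccccc3nc2Cl)c1` and compound 3 `FC(F)(F)c1cc(/C=C\c2cc3ccccc3nc2Cl)cc(C(F)(F)F)c1` share a core; compound 1 and compound 2 have the same atoms joined differently, and the difference between the two cores is not broken down here. In a functional assay on HeLa cells (Homo sapiens) for antiproliferative activity, read by sulforhodamine B assay, with a stated time of 72 h (on this read-out higher numbers stand for weaker inhibition and lower numbers for stronger inhibition), compound 1 gives 4220 nM, compound 2 gives 2850 nM and compound 3 gives 6780 nM. Going by the values given here, the one counted change, (trifluoromethyl in place of hydrogen on an aromatic carbon), moved a 2.4-fold higher number from compound 2 to compound 3 (0.38 log units; beyond the scatter).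

Compound 4 `FC(F)(F)c1ccc(/C=C\c2cc3ccccc3nc2Cl)c(C(F)(F)F)c1` carries the change (trifluoromethyl in place of hydrogen on an aromatic carbon). Among the compounds with values here, this is the same kind of change as the one from compound 2 to compound 3, not the same: the entering group is meta to a large group in compound 3 but ortho to a large group in compound 4, while in both it is meta to a trifluoromethyl group. Within the data shown here, for compound 4 the expected step in this assay is a 2.1-fold higher number from compound 1 to compound 4 (0.33 log units; beyond the scatter), a weakening of similar size to the earlier one, resting on the single measured step of a 2.4-fold higher number from compound 2 to compound 3 (0.38 log units; beyond the scatter) and on compound 1 at 4220 nM. Compound 4 is thus estimated at 9000 nM, within 4000 nM to 20000 nM.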

Compound 4, half-maximal inhibitory concentration: 35900 nM
Estimate against measurement, compound 4: 4.0-fold (0.60 log units) below, outside the stated range (above it).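

In this assay the new step is an 8.5-fold higher number from compound 1 to compound 4 (0.93 log units; beyond the scatter), with the entering trifluoromethyl ortho to a large group and meta to a trifluoromethyl group. The change gave a higher number on both cores, but the size of the step did not carry from one core to the other: the same change on two cores in this assay, a 2.4-fold higher number (0.38 log units; beyond the scatter) from compound 2 to compound 3 and an 8.5-fold higher number (0.93 log units; beyond the scatter) from compound 1 to compound 4, 3.6-fold (0.55 log units) apart, beyond the scatter of two such steps. Going by these compounds alone, with only two such steps, and the entering group ortho to a large group in only one of them, these data do not show whether that placement or some other difference between the cores sets the size, so no general rule for carrying the change across the series follows.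

The compounds shown leave open how a methoxy group, an amine or a carboxylic acid on the same aromatic carbon would compare with trifluoromethyl there. They also leave open whether steps of these sizes would recur if a nitrile stood in place of the trifluoromethyl group already present on the core.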